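This account rests on a few compounds, and the source may have more. Where it says the series, first, only, none or still open, it means among the compounds named here.

Within the data shown here, in a functional assay on CEM-DNR-bulk cells (Homo sapiens), read by MTT assay, with a stated time of 72 h (on this read-out lower numbers stand for stronger inhibition and higher numbers for weaker inhibition), compound 2 (`C#Cc1cn([C@@H]2O[C@H](CO)[C@@H](O)[C@H]2O)c2ncnc(NC)c12`) gives 18500 nM as the only true number so far. Compound 1 (`CNc1ncnc2c1c(-c1ccccc1)cn2[C@@H]1O[C@H](CO)[C@@H](O)[C@H]1O`) reads > 20000 nM in this assay and this is a limit, not a number. Compound 3 (`CNc1ncnc2c1c(I)cn2[C@@H]1O[C@H](CO)[C@@H](O)[C@H]1O`) carries iodo in place of ethynyl on an aromatic carbon and has yet to be measured. Among the measured compounds shown here, the one measured step, ethynyl in place of phenyl on an aromatic carbon, is an at least 1.0-fold lower number from compound 1 to compound 2 (0.03 log units; that floor lies within the scatter) and gives only a floor, so on this single step no shift beyond the scatter is expected in this assay for the new swap, though a somewhat lower number remains possible. The expected step is a 1.5-fold lower number from compound 2 to compound 3 (0.19 log units; within the scatter) and it is only an estimate. For compound 3 the estimated value is 12000 nM (expected range 3000 nM to 20000 nM).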

Compound 3, half-maximal inhibitory concentration: > 20000 nM
Compound 3 ended at the assay's limit (the forecaster's own chance of this, stated with the estimate: 35%); middle value at least 1.6-fold (0.22 log units) from the limit.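

Putting iodo in place of ethynyl on this aromatic carbon gives an at least 1.0-fold higher number from compound 2 to compound 3 (0.03 log units; that floor lies within the scatter), so only a floor is known and the swap shows no shift that stands out from the scatter. The step from phenyl to iodo cannot be read, since both compounds sit at a limit. A ring, a triple bond and a single iodine atom have now been compared at this position, yet little can be said about how it responds to change, because the values crowd at the top of the range: the limit of > 20000 nM in this assay, at which 2 of the 3 values shown sit.

Going by these compounds, whether any group on this carbon can bring the number well below that limit in this assay remains open. An amine, a carboxylic acid or a longer chain at this place might read differently, and the compounds shown give no hint either way.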